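This account rests on a few compounds, and the source may have more. Where it says the series, first, only, none or still open, it means among the compounds named here.

Measured in a functional assay on A-431 cells (Homo sapiens) for cytotoxicity; on this read-out higher numbers stand for an effect only at larger amounts of compound and lower numbers for an effect already at smaller amounts:
- compound 1 `COC1=C(C)C(=O)/C(=C(O)/C=C/c2ccc(Br)cc2)C(=O)C1(C)C`: 9 ug/mL
- compound 2 `COC1=C(C)C(=O)/C(=C(O)/C=C/c2ccc(O)cc2)C(=O)C1(C)C`: 14.9 ug/mL

Compound 2 at 14.9 ug/mL lies within the scatter of compound 1, so the two numbers do not separate. Compound 3 `COC1=C(C)C(=O)/C(=C(O)/C=C/c2ccccc2C)C(=O)C1(C)C` differs from compound 2 by 2-methylphenyl in place of 4-hydroxyphenyl on a double-bonded chain carbon bound to a double-bonded chain carbon, with 2-methylphenyl in place of 4-hydroxyphenyl. Among the compounds with values here, only one measured step bears on this change: a 1.7-fold higher number from compound 1 to compound 2 (0.22 log units; within the scatter), for hydroxy in place of bromo on an aromatic carbon. Within the data shown here, no measured compound carries 2-methylphenyl, so this is weak guidance, and no step beyond the scatter is expected in this assay. The expected change is a 1.4-fold lower number from compound 2 to compound 3 (0.13 log units; within the scatter). For compound 3 the estimated value is 11 ug/mL, with an expected range of 5 ug/mL to 25 ug/mL.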

Compound 3, concentration for half-maximal effect: 5.2 ug/mL
Beside the measured number, compound 3's estimate is 2.1-fold (0.33 log units) above it, within the range that was stated.
By their numbers in this assay, from the lowest: compounds 3, 1 and 2 (each within the scatter of the next, the first and the last beyond it).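

In this assay, within the data shown here, the change to 2-methylphenyl on a double-bonded chain carbon bound to a double-bonded chain carbon gives a 2.9-fold lower number from compound 2 to compound 3 (0.46 log units; beyond the scatter) as the first step beyond the scatter, so the group at this position can move the number. The same group in place of 4-bromophenyl gives a 1.7-fold lower number from compound 1 to compound 3 (0.24 log units; within the scatter) and does not separate those two compounds. No measurement shown accounts for the step.

As far as these compounds go, whether the lower number goes with the methyl group arriving or the hydroxy group leaving stays open. A 4-methylphenyl or an aminophenyl group would bear on this.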